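Chloromethylbenzyl purines: amino for chloro on the core

The source may report more compounds than this note shows. Statements on the series, on what has been measured and on what is new or still open speak of the compounds shown alone.

The compounds share a dichlorinated fused core carrying a chloromethyl-substituted benzyl group. Compound 1 `ClCc1ccccc1Cn1cnc2c(Cl)nc(Cl)nc21` bears the chloromethyl group on the benzyl ring in one arrangement; compound 2 `ClCc1cccc(Cn2cnc3c(Cl)nc(Cl)nc32)c1` is built from the same atoms joined differently, and the difference between the two cores is not broken down here. In a functional assay on SK-OV-3 cells (Homo sapiens) for cytotoxicity, read by sulforhodamine B assay, with a stated time of 48 h (on this read-out higher numbers stand for weaker inhibition of growth and lower numbers for stronger inhibition of growth), compound 1 gives 3540 nM. For compound 2 the result in this assay is "not determined" (no result reported), so there is no single number to stand beside it.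

Compound 3 `Nc1nc(Cl)c2ncn(Cc3ccccc3CCl)c2n1` differs from compound 1 by amino in place of chloro on an aromatic carbon. In this assay compound 3 gives 52500 nM. This change produced a 15-fold higher number from compound 1 to compound 3 (1.17 log units; beyond the scatter).

Among the compounds with values here, compound 4 `Nc1nc(Cl)c2ncn(Cc3cccc(CCl)c3)c2n1` has not yet been measured; it differs from compound 2 by amino in place of chloro on an aromatic carbon, which is the same change as the one from compound 1 to compound 3, at a place described in identical words. Within the data shown here, because the only measured instance of this change, a 15-fold higher number from compound 1 to compound 3 (1.17 log units; beyond the scatter), weakened growth inhibition by a large step, and because compound 1 gives 3540 nM as the only anchor in this assay for this pair of core arrangements, compound 4 is expected to fall well toward the weaker end. With compound 2 unmeasured, the starting point itself is uncertain, so the expected range is wide. Compound 4 is estimated at 50000 nM, with a plausible span from 8000 nM to 300000 nM.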

Compound 4, concentration for total growth inhibition: 67600 nM
Compound 4: middle estimate off by 1.4-fold (0.13 log units), on the low side; the measured number falls inside the stated range.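

Compound 2 has no single number in this assay, and the step from it to compound 4, which gives 67600 nM, cannot be read. The compounds shown leave open whether amino in place of chloro has the same effect in the arrangement of compound 2 as a 15-fold higher number from compound 1 to compound 3 (1.17 log units; beyond the scatter) shows in the arrangement of compound 1. No evidence shown here bears on this result.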